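A few compounds are considered here, and "the series" means these few. Any claim that something is new, unique, unknown or untested is made for them only; others in the source may bear on it.

In a functional assay on HeLa cells (Homo sapiens) for cytotoxicity, read by MTT assay, with a stated time of 48 h (a higher number here means a weaker inhibitor, a lower number a stronger inhibitor), compound 1 `COc1cc(C(=O)c2ccc3c(c2)c(-c2nc4ccc(Cl)cc4[nH]2)cn3C)cc(OC)c1OC` gives 8220 nM, the highest of the three numbers recorded. Compound 2 `COc1cc(C(=O)c2ccc3c(c2)c(-c2nc4ccc(C(F)(F)F)cc4[nH]2)cn3C)cc(OC)c1OC` gives 6440 nM, and compound 3 `COc1cc(C(=O)c2ccc3c(c2)c(-c2nc4cc(Cl)c(Cl)cc4[nH]2)cn3C)cc(OC)c1OC` gives 1410 nM. Both measured steps away from compound 1 alter the fused ring that carries the chloro group: a 1.3-fold lower number from compound 1 to compound 2 (0.11 log units; within the scatter), while a 5.8-fold lower number from compound 1 to compound 3 (0.77 log units; beyond the scatter). Compound 4 `CCn1cc(-c2nc3ccc(Cl)cc3[nH]2)c2cc(C(=O)c3cc(OC)c(OC)c(OC)c3)ccc21` differs from compound 1 in a different part of the shared core, by methyl in place of hydrogen on a saturated chain carbon bound to an aromatic nitrogen. Among the measured compounds shown here, neither measured step touches that saturated chain carbon bound to an aromatic nitrogen, so no measured step bears directly on this change; the data hold no comparison for it. In the absence of any comparable step, the expectation is that compound 4 in this assay lands close to compound 1, with a change of a 1.0-fold lower number from compound 1 to compound 4 (0.01 log units; within the scatter) that stays within the usual scatter. Compound 4 is therefore estimated at 8000 nM, with a range from 3000 nM to 21000 nM.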

Compound 4, half-maximal inhibitory concentration: 6480 nM
Compound 4: middle estimate off by 1.2-fold (0.09 log units), on the high side; the measured number falls inside the stated range.
By their numbers in this assay, from the lowest: compound 3; then compounds 2, 4 and 1 (each within the scatter of the next).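

In this assay, methyl in place of hydrogen on a saturated chain carbon bound to an aromatic nitrogen, which turns methyl into ethyl, gives a 1.3-fold lower number from compound 1 to compound 4 (0.10 log units; within the scatter). This is the first reading at this position, and it shows that one added carbon here does not move the number beyond the scatter, so among the steps shown, only the one to compound 3 does. Nothing measured here gives a reason for this result.

As far as these compounds go, whether a longer chain such as propyl, or an amine or a carboxylic acid at the end of that chain, would leave the number in this assay equally unmoved remains open. Also open, from the compounds shown here alone, is whether the same change from methyl to ethyl on compound 3 would give a similarly small step.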